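Methyl in place of bromo on the shared core

A few compounds are considered here, and "the series" means these few. Any claim that something is new, unique, unknown or untested is made for them only; others in the source may bear on it.

In a functional assay on MC-38 cells (Mus musculus) for antiproliferative activity, read by colorimetric assay and MTT assay (a higher number here means a weaker inhibitor, a lower number a stronger inhibitor), compound 2 `Nc1ccc(S(=O)(=O)Nc2ccc(Br)c3c(Cl)c[nH]c23)cc1` gives 0.14 ug/mL, and compound 1 `Nc1ccc(S(=O)(=O)Nc2cccc3c(Cl)c[nH]c23)cc1` gives 0.23 ug/mL. Among the compounds with values here, these are the only two numbers so far, and they lie within the scatter of each other. Compound 3 `Cc1ccc(NS(=O)(=O)c2ccc(N)cc2)c2[nH]cc(Cl)c12` carries methyl in place of bromo on an aromatic carbon. Within the data shown here, the one measured step that bears on this change is a 1.6-fold lower number from compound 1 to compound 2 (0.22 log units; within the scatter), with bromo in place of hydrogen on an aromatic carbon. That step stays within the scatter. Among the measured compounds shown here, no measured step covers methyl itself, so this expectation rests on a single comparison. No shift beyond the scatter is expected in this assay, and no direction is favoured. The expected size is a 1.4-fold higher number from compound 2 to compound 3 (0.15 log units; within the scatter), which is small. Compound 3 is estimated at 0.2 ug/mL, with an expected range of 0.08 ug/mL to 0.5 ug/mL.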

Compound 3, half-maximal inhibitory concentration: 0.1 ug/mL
The estimate for compound 3 lay 2.0-fold (0.30 log units) above the measured number; the measured number falls inside the stated range.
By their numbers in this assay, from the lowest: compounds 3, 2 and 1 (each within the scatter of the next, the first and the last beyond it).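

At this position, on an aromatic carbon para to a large group, methyl and bromo cannot be told apart in this assay, with a 1.4-fold lower number from compound 2 to compound 3 (0.15 log units; within the scatter). Methyl is nevertheless the first group here whose step from hydrogen clears the scatter, with a 2.3-fold lower number from compound 1 to compound 3 (0.36 log units; beyond the scatter), whereas the step from hydrogen to bromo stayed within it. No measurement at hand gives a reason for either step.

The compounds shown leave open whether a group other than methyl or bromo on this carbon, such as an amine, a methoxy group or an ethyl chain, would move the number beyond the scatter of compound 3. Also open, from the compounds shown here alone, is whether methyl keeps its step from hydrogen when the chloro group on the shared core gives way to a nitrile.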